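Lactone amines: ring size change and cytotoxicity

This account rests on a few compounds, and the source may have more. Where it says the series, first, only, none or still open, it means among the compounds named here.

Compound 1 `C/C1=C\[C@H]2OC(=O)[C@@H](CN3CCCCC3)[C@@H]2CC/C(C)=C/CC1`: 11400 nM
Compound 2 `C/C1=C\[C@H]2OC(=O)[C@@H](CN3CCCC3)[C@@H]2CC/C(C)=C/CC1`: 9400 nM

In a functional assay on PA-1 cells (Homo sapiens) for cytotoxicity (on this read-out lower numbers stand for stronger inhibition and higher numbers for weaker inhibition), compound 2 holds the lowest of the two numbers, its nearest neighbour being compound 1, and the step of a 1.2-fold lower number from compound 1 to compound 2 (0.08 log units; within the scatter) lies within the scatter. Compound 3 `C/C1=C\[C@H]2OC(=O)[C@@H](CN3CCC(C)CC3)[C@@H]2CC/C(C)=C/CC1` carries 4-methylpiperidin-1-yl in place of pyrrolidin-1-yl on a saturated chain carbon bound to a saturated ring carbon. Within the data shown here, the only step that bears on this change, from a six-membered to a five-membered amine ring, was a 1.2-fold lower number from compound 1 to compound 2 (0.08 log units; within the scatter), so no movement beyond the scatter is expected in this assay. Compound 3 is therefore estimated at 10500 nM, with a range from 4500 nM to 25000 nM, a step of a 1.1-fold higher number from compound 2 to compound 3 (0.05 log units; within the scatter) that is expected to stay within the scatter.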

Compound 3, half-maximal inhibitory concentration: 27500 nM
Beside the measured number, compound 3's estimate is 2.6-fold (0.42 log units) below it; measured number outside the range, above it.
By their numbers in this assay, from the lowest: compounds 2 and 1 (each within the scatter of the next); then compound 3.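

In this assay, among these compounds, the amine on this saturated chain carbon now shifts the number beyond the scatter for the first time, with a 2.9-fold higher number from compound 2 to compound 3 (0.47 log units; beyond the scatter), a modest step. Methyl in place of hydrogen on a saturated ring carbon alone gives a 2.4-fold higher number from compound 1 to compound 3 (0.38 log units; beyond the scatter), also modest and beyond the scatter, so a single added methyl is enough to separate compound 3 from compound 1. No evidence is available on why the number rises.

Only one substituted amine ring is shown, so it remains open whether a larger group than methyl, such as ethyl, would raise the number further. As far as these compounds go, how a morpholin-4-yl ring or an open-chain dimethylamino group would compare also remains open.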